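Bromo to trifluoromethyl on the fused ring of compound 3

This account rests on a few compounds, and the source may have more. Where it says the series, first, only, none or still open, it means among the compounds named here.

Three measured compounds share one core and differ only in the substitution pattern on the fused bicyclic part. Compound 1 `CCC(CC)(CC(=O)Nc1cccc(OCc2ccc3cccc(F)c3n2)c1)C(=O)O` gives 6 nM in a functional assay on ileum (Cavia porcellus) for antagonist activity at cysteinyl leukotriene receptor (Homo sapiens); a higher number here means a weaker inhibitor, a lower number a stronger inhibitor. Compound 2 `CCC(CC)(CC(=O)Nc1cccc(OCc2ccc3cc(F)c(F)cc3n2)c1)C(=O)O` gives 0.5 nM in this assay. Compound 3 `CCC(CC)(CC(=O)Nc1cccc(OCc2ccc3ccc(Br)cc3n2)c1)C(=O)O` gives 4 nM in this assay.

On standing: the number for compound 3 is the second highest of the three. Compound 1 is nearest, with a slightly higher number that stays within the scatter, so no order is drawn between compound 1 and compound 3. Compound 2 is furthest, with a markedly lower number that lies beyond the scatter.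

Compound 4 `CCC(CC)(CC(=O)Nc1cccc(OCc2ccc3ccc(C(F)(F)F)cc3n2)c1)C(=O)O` is not yet measured. Against compound 3 the change is trifluoromethyl in place of bromo on an aromatic carbon, a trifluoromethyl in place of bromo on an aromatic carbon, with everything else unchanged. Going by the values given here, no measured pair isolates this exchange, so there is no step to lean on. The expectation is a small step, with the move from compound 3 to compound 4 estimated at no change at the digits printed from compound 3 to compound 4 (within the scatter), in either direction and not clearly beyond the scatter. Compound 4 is estimated at 4 nM in this assay, expected to fall between 1.5 nM and 12 nM.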

Compound 4, half-maximal inhibitory concentration: 3 nM
Estimate against measurement, compound 4: 1.3-fold (0.12 log units) above; the measured number falls inside the stated range.
By their numbers in this assay, from the lowest: compound 2; then compounds 4, 3 and 1 (each within the scatter of the next).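

In this assay, going by these compounds alone, trifluoromethyl in place of bromo on this aromatic carbon gives a 1.3-fold lower number from compound 3 to compound 4 (0.12 log units; within the scatter), which is the first step that isolates a change in one place. At this position, going from one heavy atom to four, with no hydrogen-bond donor or acceptor in either group, leaves no order that can be drawn between the two compounds, so in this pair the two groups cannot be told apart by this read-out. The result comes with no measurement of any property of either group that could account for it, and the step therefore stands as an observation without an explanation.

Going by these compounds, it remains open whether a nitrile, an amine, a carboxylic acid or a longer chain on the same aromatic carbon would stay equally close to compound 3, and how a plain hydrogen there would compare. Also open, on these data alone, is whether the exchange of bromo for trifluoromethyl gives a similarly small step on other aromatic carbons of the fused system, since this single pair speaks only for this one place.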